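Pyridyl for difluorophenyl on the thiazole aryl of compound 3

A few compounds are considered here, and "the series" means these few. Any claim that something is new, unique, unknown or untested is made for them only; others in the source may bear on it.

Working notes on the thiazole acetic acid series. In an in vitro functional assay on HEK285-7 cells for antagonist activity at prostaglandin D2 receptor 2 (Homo sapiens), read by BRET and beta-arrestin recruitment (a lower number here means a stronger inhibitor, a higher number a weaker inhibitor), compound 2 `O=C(O)Cc1sc(C(c2ccccc2)c2ccc(O)cc2)nc1-c1ccc(F)cc1` gives 30 nM and compound 3 `O=C(O)Cc1sc(C(c2ccc(F)cc2)c2ccc(F)cc2)nc1-c1cc(F)cc(F)c1` gives 340 nM. Compound 3 thus stands at the higher of the two numbers, with compound 2 as its nearest neighbour, the gap between them lying beyond the scatter of this assay. Compound 1 `CCC(c1ccccc1)c1nc(-c2ccc(Cl)cc2)c(CC(=O)O)s1` returns only a limit in this assay, > 100000 nM. That limit is the limit of > 100000 nM in this assay, at which 1 of the 3 values shown sits, and it is not a number that can be ranked against the others.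

Compound 4 `CN(C)c1cc(-c2nc(C(c3ccc(F)cc3)c3ccc(F)cc3)sc2CC(=O)O)ccn1` has not yet been measured. It differs from compound 3 by 2-(dimethylamino)pyridin-4-yl in place of 3,5-difluorophenyl on an aromatic carbon. The leaving ring is of carbon only; the entering ring carries a hetero atom and a dimethylamino group. Going by the values given here, no step between measured compounds of this kind is available, so the direction rests only on the spread seen between compound 3 and compound 2, whose lower value of 30 nM shows that another aryl at this carbon can bring the number down.

The step of a 1.7-fold lower number from compound 3 to compound 4 (0.23 log units; within the scatter) is expected to be a modest lowering, close to the edge of the scatter. Compound 4 is estimated at 200 nM, within 40 nM to 1500 nM, in this assay.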

Compound 4, half-maximal inhibitory concentration: > 100000 nM
Compound 4: a limit, no number; the forecaster's own chance of this, stated with the estimate: 5%; middle value at least 500-fold (2.69 log units) away from the limit.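

Putting 2-(dimethylamino)pyridin-4-yl in place of 3,5-difluorophenyl on this aromatic carbon gives an at least 290-fold higher number from compound 3 to compound 4 (2.46 log units; beyond the scatter) in this assay. Going by these compounds alone, this is the first single-place step read at this carbon, and it shows that the change can remove measurable inhibition rather than merely shift the number within a narrow range, so the aryl group here cannot be exchanged freely. Compound 4 returns a limit and not a number, so the step gives only a bound on the size of the loss, and the reading stands at the assay's limit: the limit of > 100000 nM in this assay, at which 2 of the 4 values shown sit.

The ring nitrogen and the dimethylamino group enter together, so the compounds shown cannot say which of the two carries the step, and neither pyridin-4-yl without a substituent nor 2-methoxypyridin-4-yl is among them to separate the two. Also open, as far as these compounds go, is whether a phenyl ring bearing a dimethylamino group on this aromatic carbon would behave like compound 3 or like compound 4, and no cause for the step can be drawn from these data.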